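A few compounds are considered here, and "the series" means these few. Any claim that something is new, unique, unknown or untested is made for them only; others in the source may bear on it.

Measured compounds in an assay on isolated protein for inhibition of sodium-dependent phosphate transport protein 2B (Homo sapiens); a higher number here means a weaker inhibitor, a lower number a stronger inhibitor:
compound 1 `CCC(CC)N(CCN(C)C(=O)CCC(=O)O)Cc1cccc(C(=O)Nc2sc3c(c2C(=O)c2cnn(-c4ccc(Cl)c(C(F)(F)F)c4)c2)CCC(C)(C)C3)c1` gives 38 nM.
compound 2 `CCC(CC)N(CCN(C)C(=O)CCC(=O)O)Cc1cccc(C(=O)Nc2sc3c(c2C(=O)c2cnn(-c4ccc(Cl)cc4)c2)CCN(C(C)=O)C3)c1` gives > 1000 nM, which is a limit of this assay and not a number.
compound 3 `CCC(CC)N(CCN(C)C(=O)CCC(=O)O)Cc1cccc(C(=O)Nc2sc3c(c2C(=O)c2cnn(-c4ccc(Cl)cc4)c2)CCC(C)(C)C3)c1` gives 36 nM.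

Compound 3 carries the lowest of the two numbers shown; compound 1 sits within the scatter of it. Among the measured compounds shown here, the one step between measured neighbours, a 1.1-fold lower number from compound 1 to compound 3 (0.02 log units; within the scatter), did not move the number beyond the scatter. For the measured compounds named here, the values of compound 2 and compound 3 differ in two places and show only that compound 2 reaches the limit described by the limit of > 1000 nM in this assay, at which 1 of the 3 values shown sits.

Compound 4 `CCC(CC)N(CCN(C)C(=O)CCC(=O)O)Cc1cccc(C(=O)Nc2sc3c(c2C(=O)c2cnn(-c4cccc(C(F)(F)F)c4)c2)CCC(C)(C)C3)c1` is not yet measured. It differs from compound 3 by 3-(trifluoromethyl)phenyl in place of 4-chlorophenyl on an aromatic nitrogen. Going by the values given here, the only measured step that bears on this change is a 1.1-fold lower number from compound 1 to compound 3 (0.02 log units; within the scatter), which moved the trifluoromethyl off the same aryl ring without a shift beyond the scatter; nothing measured separates the effect of the chlorine from that of the trifluoromethyl. The step of a 1.3-fold higher number from compound 3 to compound 4 (0.10 log units; within the scatter) is therefore expected to stay small, with no direction beyond the scatter. For compound 4 a value of 45 nM is estimated, between 15 nM and 150 nM.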

Compound 4, half-maximal inhibitory concentration: 46 nM
Estimate against measurement, compound 4: 1.0-fold (0.01 log units) below; measured number inside the range.
By their numbers in this assay, from the lowest: compounds 3, 1 and 4 (each within the scatter of the next). At a limit, above all of these: compound 2.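

In this assay, the step of a 1.2-fold higher number from compound 1 to compound 4 (0.08 log units; within the scatter) takes off the chloro and keeps the trifluoromethyl, the converse of the earlier change on this aryl ring, so each substituent has now been removed singly with no shift beyond the scatter. The step of a 1.3-fold higher number from compound 3 to compound 4 (0.11 log units; within the scatter) adds that 3-(trifluoromethyl)phenyl and 4-chlorophenyl on the aromatic nitrogen cannot be told apart in this assay. Nothing measured on these compounds bears on why these exchanges leave the number within the scatter.

Still open, going by these compounds, is whether the ring needs any substituent at all, as in plain phenyl. Also open, on these data alone, is whether a methoxy, a nitrile or an amine on that ring, or a cyclohexyl group in place of the aryl ring, would keep the number within the scatter.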